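Pyridin-3-yl amide in the pyrazolopyrimidine-type series: expected value

This account rests on a few compounds, and the source may have more. Where it says the series, first, only, none or still open, it means among the compounds named here.

Three compounds of the shared core have numbers in an assay on CHO cells for displacement of a labelled ligand from adenosine receptor A3 (Homo sapiens), read by scintillation counting, with a stated time of 60 min; a higher number here means a weaker inhibitor, a lower number a stronger inhibitor. Compound 1 `Cc1nc(NC(=O)c2ccccc2)c2nn(-c3ccccc3)cc2n1`, with phenyl on the carbonyl carbon, gives 5.6 nM. Compound 2 `CC(=O)Nc1nc(C)nc2cn(-c3ccccc3)nc12`, with methyl there, gives 300 nM. Compound 3 `Cc1nc(NC(=O)c2ccncc2)c2nn(-c3ccccc3)cc2n1`, with pyridin-4-yl there, gives 5.2 nM, the lowest of the three numbers; its nearest neighbour is compound 1, within the scatter, and its furthest is compound 2.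

Within the data shown here, the steps so far: a 54-fold higher number from compound 1 to compound 2 (1.73 log units; beyond the scatter), a 1.1-fold lower number from compound 1 to compound 3 (0.03 log units; within the scatter) and a 58-fold lower number from compound 2 to compound 3 (1.76 log units; beyond the scatter). Among the measured compounds shown here, the two large steps concern methyl against an aryl group; the one aryl-to-aryl step, phenyl to pyridin-4-yl, stays within the scatter.

Compound 4 `Cc1nc(NC(=O)c2cccnc2)c2nn(-c3ccccc3)cc2n1` is not yet measured. Its change from compound 3 is pyridin-3-yl in place of pyridin-4-yl on a carbonyl carbon. For the measured compounds named here, no measured step exchanges one pyridinyl for another, so the nearest guide is the step from compound 1 to compound 3, which stayed within the scatter, while the large steps involve methyl and do not bear on this change. The expectation for compound 4 in this assay is therefore a step of a 1.2-fold higher number from compound 3 to compound 4 (0.06 log units; within the scatter), that is, none beyond the scatter. Compound 4 is estimated at 6 nM, within 2.5 nM to 15 nM.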

Compound 4, inhibition constant: 5.3 nM
Beside the measured number, compound 4's estimate is 1.1-fold (0.05 log units) above it; low and high end bracket the measured number.
By their numbers in this assay, from the lowest: compounds 3, 4 and 1 (each within the scatter of the next); then compound 2.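

In this assay, among these compounds, pyridin-3-yl in place of pyridin-4-yl on the carbonyl carbon gives a 1.0-fold higher number from compound 3 to compound 4 (0.01 log units; within the scatter), the first exchange of one pyridinyl group for another at this position, and the two groups cannot be told apart in this assay. With a 1.1-fold lower number from compound 1 to compound 4 (0.02 log units; within the scatter) as well, phenyl, pyridin-4-yl and pyridin-3-yl now all lie within the scatter of one another, while a 57-fold lower number from compound 2 to compound 4 (1.75 log units; beyond the scatter) adds a third aromatic ring that stands well away from methyl, with no compound shown going against that split. Nothing available explains either the lack of separation among the three rings or the gap to compound 2.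

Methyl is the only group on the carbonyl carbon without an aromatic ring, so a cyclohexyl ring or a longer chain such as propyl would be needed to tell whether the aromatic ring itself matters. Going by these compounds, how far the tolerance among rings extends also remains open, for instance to pyridin-2-yl or to a phenyl ring carrying a methoxy group, an amine or a carboxylic acid.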